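Swapping the bicyclic ether partner in a weak binder

This account rests on a few compounds, and the source may have more. Where it says the series, first, only, none or still open, it means among the compounds named here.

Compound 1 `Cc1ncc2nccn2c1-c1ccc(Oc2nccc3occc23)cc1C(F)(F)F` and compound 2 `FC(F)(F)c1cc(Oc2nccc3occc23)ccc1-c1cccc2nccn12` share an aryl ether core. In an assay on cells for displacement of a labelled ligand from 5-hydroxytryptamine receptor 3A (Homo sapiens), read by scintillation counting, with a stated time of 90 min (on this read-out lower numbers stand for stronger inhibition and higher numbers for weaker inhibition), compound 1 gives 9100 nM, and in this assay compound 2 gives 9300 nM. Compound 2 holds the highest of the two numbers recorded, but the step of a 1.0-fold higher number from compound 1 to compound 2 (0.01 log units; within the scatter) shows that the two values cannot be told apart. Compound 3 `FC(F)(F)c1cc(Oc2nccc3ccsc23)ccc1-c1cccc2nccn12` has not yet been measured in this assay. It differs from compound 2 by a group of 9 heavy atoms (7 carbon, 1 nitrogen, 1 sulfur; one five-membered aromatic ring with 1 hetero atom, one six-membered aromatic ring with 1 hetero atom) in place of a group of 9 heavy atoms (7 carbon, 1 nitrogen, 1 oxygen; one five-membered aromatic ring with 1 hetero atom, one six-membered aromatic ring with 1 hetero atom), on an oxygen on an aromatic ring. Among the compounds with values here, the only measured step, a 1.0-fold higher number from compound 1 to compound 2 (0.01 log units; within the scatter), concerns a different position, the group attached to the aromatic carbon, and says nothing about the ether partner; no measured pair bears directly on the change from compound 2 to compound 3. With no evidence for a shift in either direction, the expected step in this assay is no change at the digits printed from compound 2 to compound 3 (within the scatter), that is, nothing beyond the scatter. Compound 3 is therefore estimated at 9300 nM in this assay, with a range from 3000 nM to 30000 nM.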

Compound 3, inhibition constant: 7600 nM
For compound 3 the middle estimate is 1.2-fold (0.09 log units) above the measured one; the range from low to high includes it.
By their numbers in this assay, from the lowest: compounds 3, 1 and 2 (each within the scatter of the next).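

Within the data shown here, the step of a 1.2-fold lower number from compound 2 to compound 3 (0.09 log units; within the scatter) is the first measured change to the group on the oxygen, and in this assay the swap of oxygen for sulfur in that group leaves the number within the scatter. The earlier step changed only the group on the aromatic carbon, so it could not show that these two groups on the oxygen cannot be told apart at this position. Nothing available explains this result or accounts for the high numbers shared by all three compounds.

From the compounds shown here alone, whether a more different group on the same oxygen, such as a plain phenyl ring or a chain ending in an amine, would move the number beyond the scatter remains open. Going by these compounds, the sulfur-containing group has also been read only alongside the group on the aromatic carbon of compound 2, so it remains open whether the result would hold with the corresponding group of compound 1.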